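The source may report more compounds than this note shows. Statements on the series, on what has been measured and on what is new or still open speak of the compounds shown alone.

Compound 1 `CNC(=O)CNCc1ccc(OCc2cccc(Cl)c2)cc1` gives 30.5 mg/kg
Compound 2 `CNC(=O)[C@H](CO)NCc1ccc(OCc2ccccc2)cc1` gives 15 mg/kg
Compound 3 `CNC(=O)[C@H](CCSC)NCc1ccc(OCc2ccccc2)cc1` gives 239 mg/kg
Compound 4 `CC[C@H](NCc1ccc(OCc2ccccc2)cc1)C(N)=O` has no value yet

In a functional assay on the whole organism with Mus musculus as the target (on this read-out higher numbers stand for an effect only at larger amounts of compound and lower numbers for an effect already at smaller amounts), compound 2 gives 15 mg/kg and so has the lowest number of the three, which means it acts at the smallest dose. Compound 1 lies nearest to it and compound 3 furthest away.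

Compound 4 keeps the shared core but carries 1-carbamoylpropyl in place of 2-hydroxy-1-(methylcarbamoyl)ethyl on an amine nitrogen. Among the measured compounds shown here, only one measured step bears on this change. Replacing hydroxy with (methylsulfanyl)methyl on a saturated chain carbon gave a 16-fold higher number from compound 2 to compound 3 (1.20 log units; beyond the scatter) in this assay, a large move towards needing more compound. The hydroxy also leaves in compound 4, so part of that move may carry over. However, no (methylsulfanyl)methyl enters, and the change is not the same one, so a single step is thin evidence. A smaller rise in the number is the most reasonable expectation, and no change beyond the scatter remains possible.

The estimated step is a 1.9-fold higher number from compound 2 to compound 4 (0.27 log units; within the scatter) in this assay as a best guess. Compound 4 is expected at 28 mg/kg as the middle estimate, with a range from 9 mg/kg to 85 mg/kg in this read-out.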

Compound 4, dose for half-maximal effect: 119 mg/kg
Estimate against measurement, compound 4: 4.3-fold (0.63 log units) below; measured number outside the range, above it.
By their numbers in this assay, from the lowest: compound 2; then compound 1; then compounds 4 and 3 (each within the scatter of the next).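

In this assay, the replacement of the whole group on the amine nitrogen gives a 7.9-fold higher number from compound 2 to compound 4 (0.90 log units; beyond the scatter), so this position is sensitive to more than the (methylsulfanyl)methyl swap seen earlier. Both steps away from compound 2 remove the hydroxy and both raise the dose needed, even though 1-carbamoylpropyl brings in no sulfur and only a short ethyl-type end, so a bulky sulfur chain is not needed for such a rise among these compounds. No measurement shown gives a reason for this rise.

The change from compound 2 to compound 4 also alters the amide, which loses its methyl on the nitrogen, so the compounds shown cannot say how much of the step belongs to the hydroxy and how much to that methyl. A matching pair with 1-(methylcarbamoyl)propyl or 2-hydroxy-1-carbamoylethyl on the amine nitrogen would separate the two, and a methoxy or an amine at the end of the chain would show whether anything other than the hydroxy can keep the dose low.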